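Replacing sec-butyl with 3-(dibutylamino)propyl on the shared core

The compounds below may be only part of what the source reports. "The series", "measured", "known", "first", "only" and "open" are said of these compounds alone.

Compound 1 `CCCCCOc1c(-c2cc(OC)c(OC)c(OC)c2)oc2ccccc2c1=O` gives 22200 nM 
Compound 2 `CCC(C)Oc1c(-c2cc(OC)c(OC)c(OC)c2)oc2ccccc2c1=O` gives 38600 nM 

Both values come from a functional assay on PC-3 cells (Homo sapiens) for antiproliferative activity, read by WST assay, with a stated time of 3 days (a higher number here means a weaker inhibitor, a lower number a stronger inhibitor), and are all that has been measured so far. Compound 2 stands level with compound 1, since the two values lie within the scatter of each other. Compound 3 `CCCCN(CCCC)CCCOc1c(-c2cc(OC)c(OC)c(OC)c2)oc2ccccc2c1=O` has not yet been measured. It keeps the core of compound 2 and changes only the group on the oxygen: 3-(dibutylamino)propyl in place of sec-butyl on an oxygen on an aromatic ring. In words, 3-(dibutylamino)propyl comes in place of sec-butyl on an oxygen on an aromatic ring.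

For the measured compounds named here, the only measured step that bears on this is a 1.7-fold higher number from compound 1 to compound 2 (0.24 log units; within the scatter), which swapped one all-carbon chain for another. The incoming group contains nitrogen, which the chains of compound 1 and compound 2 lack, so that step is a weak guide. A larger step is expected here, probably towards a lower number, although nothing measured settles the direction. The estimated step is a 6.4-fold lower number from compound 2 to compound 3 (0.81 log units; beyond the scatter) and it carries wide uncertainty. Compound 3 is estimated at 6000 nM (expected range 1500 nM to 25000 nM).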

Compound 3, half-maximal inhibitory concentration: 7100 nM
Estimate against measurement, compound 3: 1.2-fold (0.07 log units) below; the measured number falls inside the stated range.
By their numbers in this assay, from the lowest: compound 3; then compounds 1 and 2 (each within the scatter of the next).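

In this assay, the group on this oxygen turns out to matter: 3-(dibutylamino)propyl in place of sec-butyl gives a 5.4-fold lower number from compound 2 to compound 3 (0.74 log units; beyond the scatter), and the comparison with the pentyl chain gives a 3.1-fold lower number from compound 1 to compound 3 (0.50 log units; beyond the scatter). For the compounds shown here, both steps lie beyond the scatter, whereas the earlier swap of one all-carbon chain for another did not, so this is the first sign that the number responds to a change at this position. The entering group differs from both earlier chains in two ways at once, with more heavy atoms and a nitrogen, and nothing available shows why the number falls.

The three compounds therefore leave open whether the nitrogen or the extra chain length goes with the lower number, a question that a longer all-carbon chain such as dodecyl could help to separate. They also leave open how much the butyl groups on the nitrogen contribute, which a smaller amine such as 3-(dimethylamino)propyl, or a chain ending in a piperidine ring, would begin to show.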